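The source may report more compounds than this note shows. Statements on the series, on what has been measured and on what is new or still open speak of the compounds shown alone.

Working notes on the series

Compound 3 `CNC(=O)c1cc(C(=O)NC2CC2)cn(CC2CCCCC2)c1=O` stands highest of the three numbers in a physicochemical assay for lipophilicity, at pH 7.4 (on this read-out lower numbers stand for lower lipophilicity and higher numbers for higher lipophilicity), giving 4. Its nearest neighbour is compound 1 `CNC(=O)c1cc(C(=O)NC2CC2)cn(Cc2cccc3cc[nH]c23)c1=O`, which in this assay gives 3.7, the gap being a number 0.30 log units higher from compound 1 to compound 3 (within the scatter). Furthest away is compound 2 `CNC(=O)c1cc(C(=O)NC2CC2)cn(Cc2ccc(C)cc2)c1=O`, which in this assay gives 3.5, the gap being a number 0.50 log units higher from compound 2 to compound 3 (beyond the scatter). Between the two aromatic substituents the shift is a number 0.20 log units lower from compound 1 to compound 2 (within the scatter).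

Compound 4 `CNC(=O)c1cc(C(=O)NC2CC2)cn(Cc2ccccc2F)c1=O` differs from compound 3 by 2-fluorophenyl in place of cyclohexyl on a saturated chain carbon bound to an aromatic nitrogen. Within the data shown here, the step that bears most directly on this change is the one from compound 2 to compound 3, where a six-membered aromatic ring of carbon only was replaced by a six-membered non-aromatic ring of carbon only: a number 0.50 log units higher from compound 2 to compound 3 (beyond the scatter). Going back the other way, from cyclohexyl to an aromatic ring, a shift of modest size in the downward direction is therefore expected in this assay, with a fluorine in place of a methyl on that ring possibly pulling the number a little further down, though no measured pair here tests that exchange.

For compound 4 the expected step is a number 0.70 log units lower from compound 3 to compound 4 (beyond the scatter). Compound 4 is estimated to give 3.3 in this assay, within a range of 2.8 to 3.7.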

Compound 4, distribution coefficient: 3
Beside the measured number, compound 4's estimate is 0.30 log units above it; the range from low to high includes it.
By their numbers in this assay, from the lowest: compound 4; then compounds 2, 1 and 3 (each within the scatter of the next, the first and the last beyond it).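

Among the four compounds, 2-fluorophenyl on a saturated chain carbon bound to an aromatic nitrogen gives the lowest number in this assay, and the step of a number 1.00 log units lower from compound 3 to compound 4 (beyond the scatter) is the largest seen at this position. The two earlier aromatic substituents stood within the scatter of each other, yet both now separate from 2-fluorophenyl, with a number 0.50 log units lower from compound 2 to compound 4 (beyond the scatter) and a number 0.70 log units lower from compound 1 to compound 4 (beyond the scatter) as the printed steps, so the aromatic groups at this position no longer read as a single level. No evidence on the origin of these steps is available, and they stand as observations only.

Still open, on these data alone, is how the step from cyclohexylmethyl to 2-fluorobenzyl divides between the aromatic ring and the fluorine, a question that a plain phenyl group at this place would address. Equally open is where a group carrying an amine or a carboxylic acid would fall in this assay at this place, as all substituents shown here are built from rings of carbon, with or without a small substituent.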